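The source may report more compounds than this note shows. Statements on the series, on what has been measured and on what is new or still open speak of the compounds shown alone.

Of the compounds shown here, three that share one core have been measured in a functional assay on A549 cells (Homo sapiens) for antiproliferative activity, read by MTT assay, with a stated time of 72 h; on this read-out lower numbers stand for stronger inhibition and higher numbers for weaker inhibition: compound 1 `CCOc1ccc(-c2ccc3ncn(-c4cc(OC)c(OC)c(OC)c4)c3c2)cc1` gives 8550 nM, compound 2 `COc1cc(-n2cnc3ccc(-c4ccc(C(C)=O)cc4)cc32)cc(OC)c1OC` gives 2510 nM, and compound 3 `COc1ccc(-c2ccc3ncn(-c4cc(OC)c(OC)c(OC)c4)c3c2)cc1O` gives 200 nM. Compound 3 has the lowest number of the three, and its gaps to both others lie beyond the scatter.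

Compound 4 `COc1cc(-n2cnc3ccc(-c4cc(F)ccc4F)cc32)cc(OC)c1OC` differs from compound 3 at one place: 2,5-difluorophenyl in place of 3-hydroxy-4-methoxyphenyl on an aromatic carbon. In words, 2,5-difluorophenyl stands in place of 3-hydroxy-4-methoxyphenyl on an aromatic carbon.

The measured compounds differ only in the group at this same place, so all three measured steps bear on the change. Moving to the 3-hydroxy-4-methoxyphenyl group gave large steps, a 43-fold lower number from compound 1 to compound 3 (1.63 log units; beyond the scatter) and a 13-fold lower number from compound 2 to compound 3 (1.10 log units; beyond the scatter), while the change between the other two groups gave only a modest one, a 3.4-fold lower number from compound 1 to compound 2 (0.53 log units; beyond the scatter).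

Compound 4 gives up the group that only compound 3 carries, so a large step toward a higher number is expected in this assay. The estimated change is a 15-fold higher number from compound 3 to compound 4 (1.18 log units; beyond the scatter). Among the compounds with values here, no measured compound carries fluorine, so the range is wide. For compound 4 the estimated value is 3000 nM, within a range of 600 nM to 15000 nM.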

Compound 4, half-maximal inhibitory concentration: 7940 nM
The estimate for compound 4 lay 2.6-fold (0.42 log units) below the measured number; the measured number falls inside the stated range.
By their numbers in this assay, from the lowest: compound 3; then compound 2; then compounds 4 and 1 (each within the scatter of the next).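

In this assay the swap to 2,5-difluorophenyl gives a 40-fold higher number from compound 3 to compound 4 (1.60 log units; beyond the scatter) and shows that a third group at this place also falls far short of the 3-hydroxy-4-methoxyphenyl group. Against the 4-acetylphenyl group it gives a 3.2-fold higher number from compound 2 to compound 4 (0.50 log units; beyond the scatter) as a modest step, while against the 4-ethoxyphenyl group it gives a 1.1-fold lower number from compound 1 to compound 4 (0.03 log units; within the scatter) and stays within the scatter. Among the four groups now seen at this place, 3-hydroxy-4-methoxyphenyl alone stands well apart, and a phenyl ring carrying two fluorines does not come close to it.

No evidence at hand explains this gap. Still open, as far as these compounds go, is whether the hydroxyl or the methoxy matters more, and how a phenyl ring carrying an amine or a carboxylic acid in place of the hydroxyl would compare.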